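This account rests on a few compounds, and the source may have more. Where it says the series, first, only, none or still open, it means among the compounds named here.

The measured compounds are these:
Compound 1, `Cc1ccc2nc(-c3ccc([N+](=O)[O-])cc3)cn2c1`, which in a functional assay on A549 cells (Homo sapiens) for antiproliferative activity, read by MTT assay, with a stated time of 72 h (a lower number here means a stronger inhibitor of growth, a higher number a weaker inhibitor of growth), reaches only the limit of the assay, > 100000 nM.
Compound 2, `Cc1ccc2nc(-c3ccc(N)cc3)cn2c1`, which in this assay likewise reaches only the limit of the assay, > 100000 nM.
Compound 3, `Cc1ccn2cc(-c3ccc([N+](=O)[O-])cc3)nc2c1`, which in this assay gives 62400 nM.

Compound 3 is thus the only one of the three with a number rather than a limit; the other two sit at the limit of > 100000 nM in this assay, at which 2 of the 3 values shown sit. Compound 1 and compound 2 differ by one change, (amino in place of nitro on an aromatic carbon), and the step that the two limits leave unreadable from compound 1 to compound 2 cannot be read because both values are limits. The two cores of compound 1 and compound 3 are built from the same atoms joined differently, and the difference between the two cores is not broken down here.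

Compound 4, `Cc1ccn2cc(-c3ccc(N)cc3)nc2c1`, has not yet been measured in this assay. It differs from compound 3 by amino in place of nitro on an aromatic carbon, the same change that separates compound 1 from compound 2. Since the earlier step from compound 1 to compound 2 is unreadable, the size of the step in this assay from compound 3 to compound 4 is expected on the basis of compound 3 alone, whose value is 62400 nM, so a small step, a 1.4-fold higher number from compound 3 to compound 4 (0.16 log units; within the scatter), is estimated. Compound 4 is therefore expected to give about 90000 nM in this assay, with an estimated range from 30000 nM to 300000 nM, and a fair chance that only a limit is reported.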

Compound 4, concentration for 50% growth inhibition: > 100000 nM
Compound 4 gave a limit, no number (the forecaster's own chance of this, stated with the estimate: 50%); middle value at least 1.1-fold (0.04 log units) away from the limit.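

Carried to the core of compound 3, amino in place of nitro gives, in this assay, an at least 1.6-fold higher number from compound 3 to compound 4 (0.20 log units; that floor lies within the scatter). Among these compounds, this shows only that the change does not lower the number on this core: compound 4 gives a limit rather than a number, so the step has a floor and no size, and since that floor lies within the scatter, no real loss of growth inhibition can be claimed either. It does not show that the change acts alike on the two cores, since the step between compound 1 and compound 2 cannot be read, both values being limits, which leaves nothing to set the new step against.

The compounds shown leave open whether a group other than nitro or amino at the same place, such as a carboxylic acid or a nitrile, would give a clear number in this assay, where most of the series gives no number at all: the limit of > 100000 nM in this assay, at which 3 of the 4 values shown sit. They also leave open whether a longer chain in place of the methyl on either core would move these values.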